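The compounds below may be only part of what the source reports. "The series", "measured", "known", "first", "only" and "open" are said of these compounds alone.

Measured compounds in a functional assay on B16-F10 cells (Mus musculus) for antiproliferative activity, read by MTT assay, with a stated time of 48 h; on this read-out lower numbers stand for stronger inhibition and higher numbers for weaker inhibition:
- compound 1 `CCCCOc1ccc(C(=O)/C=C/c2c(/C=C/c3ccc(OC)cc3)cc(OC)cc2OC)cc1`: 5.3 ug/mL
- compound 2 `COc1ccc(/C=C/c2cc(OC)cc(OC)c2/C=C/C(=O)c2ccc(Br)cc2)cc1`: 6.5 ug/mL
- compound 3 `COc1ccc(/C=C/c2cc(OC)cc(OC)c2/C=C/C(=O)c2ccc(F)cc2)cc1`: 5.3 ug/mL

Compound 3 stands level with compound 1 at the digits printed, the two together giving the lowest numbers of the three; the remaining step is a 1.2-fold lower number from compound 2 to compound 3 (0.09 log units; within the scatter), which is within the scatter. All three compounds share the same core and differ only at one aromatic carbon.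

Compound 4 `CCN(CC)c1ccc(C(=O)/C=C/c2c(/C=C/c3ccc(OC)cc3)cc(OC)cc2OC)cc1` continues this series at that same position: diethylamino in place of fluoro on an aromatic carbon

Within the data shown here, the steps that bear on it are the three swaps already seen at this carbon: a 1.2-fold higher number from compound 1 to compound 2 (0.09 log units; within the scatter), no change at the digits printed from compound 1 to compound 3 (within the scatter) and a 1.2-fold lower number from compound 2 to compound 3 (0.09 log units; within the scatter). None of them moved the number beyond the scatter, whether the group was butoxy, bromo or fluoro. Among the measured compounds shown here, no measured step covers diethylamino or any nitrogen-bearing group here, so the expectation rests on the position having been tolerant so far. For compound 4 a step of a 1.0-fold higher number from compound 3 to compound 4 (0.02 log units; within the scatter) is expected, that is, no movement beyond the scatter in either direction. Compound 4 is therefore estimated at 5.5 ug/mL, with a range of 2.5 ug/mL to 12 ug/mL.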

Compound 4, half-maximal inhibitory concentration: 8.1 ug/mL
For compound 4 the middle estimate is 1.5-fold (0.17 log units) below the measured one; the range from low to high includes it.
By their numbers in this assay, from the lowest: compounds 1, 3, 2 and 4 (each within the scatter of the next).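

In this assay a nitrogen-bearing group now sits at this carbon, and the number stays within the scatter of all three earlier groups: there is a 1.5-fold higher number from compound 3 to compound 4 (0.18 log units; within the scatter), there is a 1.2-fold higher number from compound 2 to compound 4 (0.10 log units; within the scatter) and there is a 1.5-fold higher number from compound 1 to compound 4 (0.18 log units; within the scatter). The tolerance seen with butoxy, bromo and fluoro therefore extends to diethylamino, which carries more heavy atoms than fluoro and adds a hydrogen-bond acceptor, so this position has not yet separated any of the four groups. Nothing measured on these compounds offers an explanation for this flat picture.

The compounds shown leave open whether a primary amine, a carboxylic acid or a chain longer than butoxy at this carbon would stay within the same scatter. They also leave open whether diethylamino would behave the same way at another carbon of that ring.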